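The compounds below may be only part of what the source reports. "The series", "measured", "known", "first", "only" and "open" are said of these compounds alone.

Compound 2 `CCCC[C@H](CO)Nc1nc(N)nc2cccnc12` has the lowest number of the two measured compounds in an assay on tissue (PBMC cells) for agonist activity at Toll-like receptor 8 (Homo sapiens), with a stated time of 24 h; on this read-out lower numbers stand for an effect already at smaller amounts and higher numbers for an effect only at larger amounts of compound: compound 2 gives 790 nM, while compound 1 `CCC[C@H](CO)Nc1nc(N)nc2cccnc12` gives 19000 nM. Within the data shown here, the two differ only in the length of the saturated chain, and that step, a 24-fold lower number from compound 1 to compound 2 (1.38 log units; beyond the scatter), is the one measured change that bears on what follows. Compound 3 `CCCCC[C@H](CO)Nc1nc(N)nc2cccnc12` is not yet measured; it differs from compound 2 by methyl in place of hydrogen on a saturated chain carbon, five bonds along the chain from a nitrogen on an aromatic ring. This is the same kind of lengthening as the step from compound 1 to compound 2, carried one bond further out. A second lengthening need not repeat a gain of that size, and a single measured step gives no sign of where the gain levels off. Compound 3 is therefore expected to give a somewhat lower number than compound 2, an estimated 2.6-fold lower number from compound 2 to compound 3 (0.42 log units; beyond the scatter). The estimate for compound 3 is 300 nM, with a range from 80 nM to 1500 nM.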

Compound 3, half-maximal effective concentration: 3330 nM
The estimate for compound 3 lay 11-fold (1.05 log units) below the measured number; measured number outside the range, above it.
By their numbers in this assay, from the lowest: compound 2; then compound 3; then compound 1.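

At this place, five bonds along the chain from a nitrogen on an aromatic ring, the added methyl reverses the direction seen one bond closer in: this assay shows a 4.2-fold higher number from compound 2 to compound 3 (0.62 log units; beyond the scatter), whereas the earlier lengthening lowered the number. Lengthening the chain therefore does not keep lowering the number, and among these three compounds the lowest number belongs to the middle chain length, that of compound 2. Part of the earlier gain survives, with a 5.7-fold lower number from compound 1 to compound 3 (0.76 log units; beyond the scatter), but nothing at hand explains why the direction turns.

On these data alone, whether a still longer chain raises the number further, or the number settles, remains open. Also open, as far as these compounds go, is what an amine or a carboxylic acid in place of this methyl would do in this assay.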